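Methyl for Hydrogen on a Chain Carbon, Two Cores

The source may hold more compounds than are shown below. What is called first, only, known or untested is meant among the compounds shown, and "the series" means these compounds.

Compound 1 `CCOC(=O)C1=C(C)N(C)C(=O)NC1c1cccs1` and compound 2 `CCCOC(=O)C1=C(C)N(C)C(=O)NC1c1cccs1` share one core. In an assay on membranes from CHO cells for displacement of a labelled ligand from adenosine receptor A1 (Homo sapiens), read by scintillation counting, with a stated time of 60 min, tested at 1 uM (a higher number here means more inhibition at the concentration tested (going by the name of the read-out), a lower number less inhibition), compound 1 gives 1% and compound 2 gives 9%. The change between them, (methyl in place of hydrogen on a saturated chain carbon, two bonds along the chain from an oxygen next to a carbonyl group), made the step of a number 8 percentage points higher from compound 1 to compound 2 (within the scatter). Compound 3 `CCCC(=O)C1=C(C)NC(=O)NC1c1ccoc1` rests on a different core; the difference between the two cores is not broken down here. In this assay compound 3 gives 1%, level with compound 1. Compound 4 `CC1=C(C(=O)CC(C)C)C(c2ccoc2)NC(=O)N1` differs from compound 3 by methyl in place of hydrogen on a saturated chain carbon bound to two saturated chain carbons, the same kind of change as that from compound 1 to compound 2, though the place differs: here the carbon is bound to two saturated chain carbons rather than standing two bonds along the chain from an oxygen next to a carbonyl group. Because that earlier change gave only a number 8 percentage points higher from compound 1 to compound 2 (within the scatter), a similarly small step a number 4 percentage points higher from compound 3 to compound 4 (within the scatter) is expected. Compound 4 is therefore estimated at 5%, between -5% and 16%.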

Compound 4, a percentage reported as inhibition, at one concentration (the size of the read-out at that concentration, not a potency): 23%
The estimate for compound 4 lay 18 percentage points below the measured number; the measured number lies above the stated range.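

On the second core, the change gave a number 22 percentage points higher from compound 3 to compound 4 (beyond the scatter) in this assay. Set beside the earlier step, this one does not differ from it by more than the scatter, so the data give no sign that the change behaves differently on the two cores: the same change on two cores in this assay, a number 8 percentage points higher (within the scatter) from compound 1 to compound 2 and a number 22 percentage points higher (beyond the scatter) from compound 3 to compound 4, 14 percentage points apart, within the scatter of two such steps This does not show that the change acts alike on both cores, for each core offers only one pair and the added methyl stands in a different place in each.

The compounds shown leave open how a longer chain or a chain ending in an amine would read in this assay on either core. They also leave open what the same chain would give when carried unchanged from one core to the other.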